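Aryl swap on the thiazole of the acid series

This account rests on a few compounds, and the source may have more. Where it says the series, first, only, none or still open, it means among the compounds named here.

All three measured members share one core, carrying an acetic acid chain and an ether-linked heteroaryl methyl group. Compound 1 `O=C(O)CC1COc2cc(OCc3nc(-c4ccccc4)cs3)ccc21` gives 0.16% in a functional assay on CHO cells for agonist activity at Free fatty acid receptor 1 (Homo sapiens), read by FLIPR and calcium flux, tested at 100 nM; a higher number here means a stronger effect of the compound at the concentration tested, a lower number a weaker effect. Compound 2 `Cc1nc(-c2ccccc2)oc1COc1ccc2c(c1)OCC2CC(=O)O` gives 7.15% in this assay. Compound 3 `Cc1nc(-c2ccc(Cl)s2)sc1COc1ccc2c(c1)OCC2CC(=O)O` gives 8.34% in this assay. The three readings are not separated: compound 3 differs from compound 2 and from compound 1 by less than the usual scatter, so none of them can be set apart from the others on these numbers alone.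

Compound 4 `Cc1cccc(-c2nc(C)c(COc3ccc4c(c3)OCC4CC(=O)O)s2)c1` is not yet measured. It differs from compound 3 in one place: 3-methylphenyl in place of 5-chlorothiophen-2-yl on an aromatic carbon. Compound 2 also carries an unsubstituted phenyl on its five-membered ring and reads 7.15%, so a carbon-only aryl at this position has not by itself moved the reading. Going by the values given here, no step between measured pairs differing in one place is available to size this change, so the expectation rests on the spread of the three values only. The expected step from compound 3 to compound 4 in this assay is a number 2.3 percentage points lower from compound 3 to compound 4 (within the scatter), which is no change beyond the scatter. Compound 4 is therefore estimated at 6% in this assay, with a range from 0% to 20%.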

Compound 4, a percentage reported as activity, at one concentration (the size of the read-out at that concentration, not a potency): 47.2%
Estimate against measurement, compound 4: 41.2 percentage points below; the measured number lies above the stated range.
By their numbers in this assay, from the lowest: compounds 1, 2 and 3 (each within the scatter of the next); then compound 4.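

In this assay, going by these compounds alone, putting 3-methylphenyl in place of 5-chlorothiophen-2-yl on an aromatic carbon of the five-membered aromatic ring with 1 nitrogen and 1 sulfur gives a number 38.9 percentage points higher from compound 3 to compound 4 (beyond the scatter) and so separates a pair of compounds for the first time. The reading is therefore sensitive to the aryl group at this position, a point that the earlier values, all within the scatter of one another, could not establish. The exchange alters several things at once, replacing a five-membered aromatic ring with 1 hetero atom and a chlorine by a six-membered aromatic ring of carbon only and a methyl group, and no measured evidence is available to explain the rise.

The compounds shown leave open whether the gain belongs to the six-membered ring itself or to its methyl group, a question that unsubstituted phenyl and 3-chlorophenyl on this same scaffold would address. Also open, from the compounds shown here alone, is how a methoxy group or a trifluoromethyl group in place of that methyl would read in this assay on this scaffold.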